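Benzyl substituent exchange: fluoro to methoxy on compound 2

The source may hold more compounds than are shown below. What is called first, only, known or untested is meant among the compounds shown, and "the series" means these compounds.

Two members of the series carry numbers in a functional assay on BT-549 cells (Homo sapiens) for inhibition, read by sulforhodamine B assay, with a stated time of 48 h (on this read-out lower numbers stand for higher toxicity in this test and higher numbers for lower toxicity in this test), so far. Compound 1 `COc1ccc(CNc2nc3cc(N)cc(N)c3nc2-c2ccccc2)cc1OC` bears a 3,4-dimethoxybenzyl group on the ring nitrogen, and in this assay compound 1 gives 79400 nM. Compound 2 `Nc1cc(N)c2nc(-c3ccccc3)c(NCc3ccc(F)cc3)nc2c1` bears a 4-fluorobenzyl group instead, and in this assay compound 2 gives 6310 nM. Among the compounds with values here, the only measured step is a 13-fold lower number from compound 1 to compound 2 (1.10 log units; beyond the scatter). Compound 2 thus stands at the lowest of the two numbers, with compound 1 as its nearest neighbour at the higher end.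

Compound 3 `COc1ccc(CNc2nc3cc(N)cc(N)c3nc2-c2ccccc2)cc1` is next. Its difference from compound 2 is methoxy in place of fluoro on an aromatic carbon. Within the data shown here, only the step from compound 1 to compound 2 bears on this, and that step combined the removal of two methoxy groups with the arrival of a fluoro. Compound 3 keeps a single methoxy where compound 2 has fluoro, so it sits between the two measured structures. The expected step is a 3.2-fold higher number from compound 2 to compound 3 (0.50 log units; beyond the scatter), a partial move back toward the number of compound 1, short of a full reversal. Compound 3 is estimated at 20000 nM, with a range from 6000 nM to 60000 nM.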

Compound 3, concentration lethal to 50% of the cells: < 100000 nM
Compound 3: only a limit was reported; the forecaster's own chance of this, stated with the estimate: 5%; the middle value does not contradict the limit.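

Compound 3 carries only a limit, < 100000 nM, so neither the step to it from compound 2 nor the step to it from compound 1 can be read: the limit of < 100000 nM in this assay, at which 1 of the 3 values shown sits.

The compounds shown leave open whether the 4-methoxybenzyl group of compound 3 gives a number closer to that of compound 2 or that of compound 1.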